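This account rests on a few compounds, and the source may have more. Where it says the series, first, only, none or still open, it means among the compounds named here.

Measured in a physicochemical assay for lipophilicity, at pH 7.4; a lower number here means a more polar compound, a higher number a more lipophilic compound:
- compound 1 `CNC(=O)c1cc(C(=O)N[C@H]2[C@@H]3COC[C@@H]32)cc2c1OC[C@H]2c1ccc(F)cc1`: 3.6
- compound 2 `CNC(=O)c1cc(C(=O)N[C@H]2[C@@H]3COC[C@@H]32)cc2c1OC[C@H]2c1ccccn1`: 1.6

Of the two, compound 2 stands lower at 1.6. For the measured compounds named here, one measured step bears on what follows: a number 2.00 log units lower from compound 1 to compound 2 (beyond the scatter), a large step beyond the scatter, with pyridin-2-yl in place of 4-fluorophenyl on a saturated ring carbon. Compound 3 `CNC(=O)c1cc(C(=O)N[C@H]2[C@@H]3COC[C@@H]32)cc2c1OC[C@H]2c1ccccc1C` has 2-methylphenyl in place of pyridin-2-yl on a saturated ring carbon. This restores an aromatic ring of carbon only, as in compound 1 at 3.6, so a large upward step in this assay is expected. The expected change is a number 2.00 log units higher from compound 2 to compound 3 (beyond the scatter). Compound 3 is estimated at 3.6, with a range of 3.1 to 4.1.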

Compound 3, distribution coefficient: 4
Beside the measured number, compound 3's estimate is 0.40 log units below it; low and high end bracket the measured number.
By their numbers in this assay, from the lowest: compound 2; then compound 1; then compound 3.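

In this assay the saturated ring carbon now shows a number 2.40 log units higher from compound 2 to compound 3 (beyond the scatter) and also a number 0.40 log units higher from compound 1 to compound 3 (beyond the scatter) for a change between two aromatic rings of carbon only. So 2-methylphenyl and 4-fluorophenyl do not read alike at this position, although the gap between them is much smaller than the gap from either to pyridin-2-yl. Nothing measured here gives a reason for these differences. The compounds leave open whether the methyl or the absent fluorine accounts for the smaller step, and how a phenyl ring carrying an amine or a carboxylic acid would read at this carbon.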